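Lengthening the Selenium-Bearing Chain on a Shared Core

The compounds below may be only part of what the source reports. "The series", "measured", "known", "first", "only" and "open" are said of these compounds alone.

Of the compounds shown here, three sharing one core have been measured in a functional assay on RKO cells (Homo sapiens) for inhibition, read by MTT assay, with a stated time of 48 h; a lower number here means a stronger inhibitor, a higher number a weaker inhibitor. Compound 1 (`COc1ccc(N(C)c2nc(C)nc3ccccc23)cc1C(=O)OCC[Se]C#N`) gives 2390 nM, and compound 2 (`COc1ccc(N(C)c2nc(C)nc3ccccc23)cc1C(=O)NCC[Se]C#N`) gives 1170 nM. Compound 3 (`COc1ccc(N(C)c2nc(C)nc3ccccc23)cc1OCC[Se]C#N`) gives 27 nM, the lowest of the three numbers and the strongest inhibitor so far. The next structure, compound 4 (`COc1ccc(N(C)c2nc(C)nc3ccccc23)cc1OCCCC[Se]C#N`), differs from compound 3 by a group of 5 heavy atoms (3 carbon, 1 nitrogen, 1 selenium; no ring) in place of a group of 3 heavy atoms (1 carbon, 1 nitrogen, 1 selenium; no ring), on a saturated chain carbon, two bonds along the chain from an oxygen on an aromatic ring.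

Among the measured compounds shown here, no measured step isolates this kind of change, so the evidence is only indirect. The change on the carbonyl carbon gave a 2.0-fold lower number from compound 1 to compound 2 (0.31 log units; beyond the scatter). The two changes on the aromatic carbon were larger, giving an 89-fold lower number from compound 1 to compound 3 (1.95 log units; beyond the scatter) and a 43-fold lower number from compound 2 to compound 3 (1.64 log units; beyond the scatter). Those large steps replaced the whole group on the aromatic carbon, whereas compound 4 keeps the oxygen on the aromatic ring and alters the group further along the chain. A step of that large size is therefore not expected here, though the data cannot rule one out. A modest rise in this assay is expected, with no change beyond the scatter also possible. The estimated step is a 1.9-fold higher number from compound 3 to compound 4 (0.27 log units; within the scatter). For compound 4 the estimated value is 50 nM, within an expected range of 12 nM to 220 nM.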

Compound 4, half-maximal inhibitory concentration: 1360 nM
Beside the measured number, compound 4's estimate is 27-fold (1.43 log units) below it; the measured number lies above the stated range.
By their numbers in this assay, from the lowest: compound 3; then compounds 2, 4 and 1 (each within the scatter of the next, the first and the last beyond it).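

In this assay, among the compounds shown here, the chain on the aromatic oxygen proved as sensitive as the group on the aromatic carbon: lengthening it alone gave a 50-fold higher number from compound 3 to compound 4 (1.70 log units; beyond the scatter) and so matched in size the earlier steps that replaced the whole group. The low number of compound 3 therefore depends on the length of this chain and not merely on the oxygen on the aromatic ring, as a 1.2-fold higher number from compound 2 to compound 4 (0.07 log units; within the scatter) and a 1.8-fold lower number from compound 1 to compound 4 (0.24 log units; within the scatter) both lie within the scatter, leaving the longer-chain compound with no measurable advantage over the compounds with a carbonyl on the aromatic carbon. Nothing available explains why this lengthening has so large an effect.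

The compounds shown leave open how the number changes with chain length, since they include no chain longer than that of compound 4, none shorter than that of compound 3, and none of a length that exceeds the chain of compound 3 yet falls short of the chain of compound 4. They also leave open whether a sulfur atom in place of the selenium would keep the low number of compound 3 on the same chain.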